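Swapping a Saturated Ring for an Aromatic One

A few compounds are considered here, and "the series" means these few. Any claim that something is new, unique, unknown or untested is made for them only; others in the source may bear on it.

Going by the values given here, compound 2 `CCCCNc1nc(N)nc(C)c1CCCN1CCCCCC1` gives 178 nM in an assay on HEK293 cells for agonist activity at Toll-like receptor 8 (Homo sapiens), read by spectrophotometry (a lower number here means that less compound is needed, a higher number that more compound is needed for the effect), the lowest of the two numbers measured so far, while compound 1 `CCCCNc1nc(N)nc(C)c1CC` gives 1660 nM in this assay. Compound 3 `CCCCNc1nc(N)nc(C)c1CCCn1cccn1` carries 1H-pyrazol-1-yl in place of azepan-1-yl on a saturated chain carbon, three bonds along the chain from an aromatic carbon. Among the compounds with values here, no measured pair of compounds mirrors this exchange; the gap between compound 1 and compound 2 only shows that what sits at the end of this chain matters a great deal. A step of a 3.4-fold higher number from compound 2 to compound 3 (0.53 log units; beyond the scatter) toward a higher number is expected, beyond the scatter. The value of compound 3 is estimated at 600 nM, within a range from 200 nM to 2000 nM.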

Compound 3, half-maximal effective concentration: 1050 nM
Estimate against measurement, compound 3: 1.8-fold (0.24 log units) below, and the stated range covers the measured number.
By their numbers in this assay, from the lowest: compound 2; then compounds 3 and 1 (each within the scatter of the next).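

In this assay, the exchange of azepan-1-yl for 1H-pyrazol-1-yl brings a 5.9-fold higher number from compound 2 to compound 3 (0.77 log units; beyond the scatter) and so shows that the kind of ring at this chain end matters. The comparison with the compound lacking this ring gives a 1.6-fold lower number from compound 1 to compound 3 (0.20 log units; within the scatter) and so no clear difference, which means that adding 1H-pyrazol-1-yl here does not by itself bring the low number of compound 2. Nothing measured here explains the difference between the two rings. Still open, as far as these compounds go, is whether piperidine or a simple diethylamino group would keep that low number. Imidazole in the same place might also behave differently from 1H-pyrazol-1-yl.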